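A few compounds are considered here, and "the series" means these few. Any claim that something is new, unique, unknown or untested is made for them only; others in the source may bear on it.

Measured in an ADME assay on microsomes from liver (Homo sapiens) for metabolic stability; on this read-out higher numbers stand for fast clearance and lower numbers for slow clearance:
- compound 1 `Cc1ccc([C@H](C)NC(=O)Cn2nnc3ccccc3c2=O)cc1`: < 9.9 mL/min/kg (a limit)
- compound 2 `Cc1ccc([C@@H](C)NC(=O)Cn2nnc3ccccc3c2=O)cc1`: < 9.9 mL/min/kg (a limit)
- compound 3 `Cc1ccc([C@H](C)NC(=O)Cn2nnc3ccccc3c2=O)c(F)c1`: 28 mL/min/kg

Compound 1 has no exact number in this assay. Compound 1 gives < 9.9 mL/min/kg, which is a limit of the assay. Its position is therefore (the limit of < 9.9 mL/min/kg in this assay, at which 2 of the 3 values shown sit), so any step away from compound 1 can only be read in part.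

Compound 4 `COc1cccc2nnn(CC(=O)N[C@@H](C)c3ccc(C)cc3)c(=O)c12` keeps the structure of compound 1 apart from one change: methoxy in place of hydrogen on an aromatic carbon. In words, this is methoxy in place of hydrogen on an aromatic carbon.

Two measured steps are available. Among the compounds with values here, the first is a step that the two limits leave unreadable from compound 1 to compound 2. It concerns (the fact that compounds 1 and 2 differ only in the configuration as drawn), so it offers little guidance on a new group. The second is an at least 2.8-fold higher number from compound 1 to compound 3 (0.45 log units; beyond the scatter). It is the closer parallel, as it too adds a new substituent to an aromatic ring, although the group and its place both differ from those in compound 4. A single step of this kind is thin support, so only a modest rise is expected, possibly one that stays hidden behind the limit.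

The step expected is an at least 1.4-fold higher number from compound 1 to compound 4 (0.15 log units; that floor lies within the scatter), an estimate that carries real uncertainty. For compound 4 the expected value is 14 mL/min/kg. The estimated range for compound 4 runs from 7 mL/min/kg to 30 mL/min/kg.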

Compound 4, clearance: 48 mL/min/kg
Estimate against measurement, compound 4: 3.4-fold (0.54 log units) below; measured number outside the range, above it.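

In this assay, methoxy in place of hydrogen, on an aromatic carbon of the six-membered aromatic ring of carbon only, ortho to a fused ring, gives an at least 4.8-fold higher number from compound 1 to compound 4 (0.68 log units; beyond the scatter). Before this result the only readable substituent step was fluoro in place of hydrogen at a different place, an at least 2.8-fold higher number from compound 1 to compound 3 (0.45 log units; beyond the scatter), so this result adds a second place on the molecule where one new group raises the clearance number clearly. The true size of the new step cannot be fixed and may be larger than its floor, because compound 1 has no exact number, only a limit: the limit of < 9.9 mL/min/kg in this assay, at which 2 of the 4 values shown sit.

The compounds shown leave open whether this rise belongs to methoxy itself or would come with other groups at the same place, such as a hydroxyl, a nitrile or a longer ether like ethoxy. They also give no measured explanation of the rise, so nothing here shows which part of compound 4 is responsible for the higher number in this assay.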